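The compounds below may be only part of what the source reports. "The series", "measured", "known", "first", "only" and "open" are said of these compounds alone.

Compound 1 `Cn1c(-c2ccc(NC(=O)CSc3nc4cc(Cl)ccc4o3)cc2)nc(-c2ccccc2)c1-c1ccccc1`: 11.9% in a functional assay on HT-29 cells (Homo sapiens) for cytotoxicity, read by MTT assay, with a stated time of 24 h, tested at 0.64 ug/mL; on this read-out higher numbers stand for a stronger effect at the one concentration tested and lower numbers for a weaker effect.
Compound 2 `Cn1ccnc1SCC(=O)Nc1ccc(-c2nc(-c3ccccc3)c(-c3ccccc3)n2C)cc1`: 13.6% in this assay.
Compound 3 `CN1CCN(CC(=O)Nc2ccc(-c3nc(-c4ccccc4)c(-c4ccccc4)n3C)cc2)CC1`: 18.8% in this assay.

Compound 3 holds the highest of the three numbers, yet a number 6.9 percentage points higher from compound 1 to compound 3 (within the scatter) and a number 5.2 percentage points higher from compound 2 to compound 3 (within the scatter) both lie within the scatter, as does a number 1.7 percentage points higher from compound 1 to compound 2 (within the scatter). Compound 4 `CCN1CCN(CC(=O)Nc2ccc(-c3nc(-c4ccccc4)c(-c4ccccc4)n3C)cc2)CC1` differs from compound 3 by methyl in place of hydrogen on a saturated chain carbon bound to an amine nitrogen in a ring. Within the data shown here, none of the measured steps touches this position; all three exchanged the entire group on the chain carbon bound to the carbonyl carbon and still remained within the scatter. A smaller change at the amine nitrogen in the ring is therefore expected to produce no step beyond the scatter in this assay, so that a number 0.2 percentage points higher from compound 3 to compound 4 (within the scatter) is expected. Compound 4 is estimated at 19%, between 8% and 30%.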

Compound 4, a percentage reported as activity, at one concentration (the size of the read-out at that concentration, not a potency): 7.4%
Compound 4: middle estimate off by 11.6 percentage points, on the high side, outside the stated range (below it).
By their numbers in this assay, from the lowest: compounds 4, 1, 2 and 3 (each within the scatter of the next, the first and the last beyond it).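

Methyl in place of hydrogen on a saturated chain carbon bound to an amine nitrogen in a ring gives in this assay the only step beyond the scatter among these compounds, with a number 11.4 percentage points lower from compound 3 to compound 4 (beyond the scatter) as its size. The exchanges of the whole group on the chain carbon bound to the carbonyl carbon stay within the scatter, with a number 6.2 percentage points lower from compound 2 to compound 4 (within the scatter) and a number 4.5 percentage points lower from compound 1 to compound 4 (within the scatter) as their sizes, so only 4-methylpiperazin-1-yl stands apart from 4-ethylpiperazin-1-yl. No measurement given here accounts for this step.

The compounds shown leave open how a propyl chain, a 2-hydroxyethyl group or a hydrogen on that ring nitrogen would read.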